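The source may hold more compounds than are shown below. What is called first, only, known or untested is meant among the compounds shown, and "the series" means these compounds.

Among the measured compounds shown here, compound 3, `CN1C(=S)[C@@H](NC(=O)c2nc(Cc3ccccc3)n(CCCCCC#N)n2)COc2ccccc21`, stands at the top of the three numbers so far in a functional assay on HT-29 cells (Homo sapiens) for inhibition, read by luminescence and CellTiter-Glo, with a stated time of 24 h (on this read-out lower numbers stand for an effect already at smaller amounts and higher numbers for an effect only at larger amounts of compound), giving 3830 nM. Its nearest neighbour is compound 2, `CN1C(=S)[C@@H](NC(=O)c2nc(Cc3ccccc3)n(CCCC#N)n2)COc2ccccc21`, which gives 2400 nM, and the step of a 1.6-fold higher number from compound 2 to compound 3 (0.20 log units; within the scatter). Furthest away lies compound 1, `CN1C(=S)[C@@H](NC(=O)c2nc(Cc3ccccc3)n(CCC(F)(F)F)n2)COc2ccccc21`, which gives 1550 nM; the step of a 2.5-fold higher number from compound 1 to compound 3 (0.39 log units; beyond the scatter). Between the other two, the step of a 1.5-fold higher number from compound 1 to compound 2 (0.19 log units; within the scatter).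

Compound 4, `CN1C(=S)[C@@H](NC(=O)c2nc(Cc3ccccc3)n(C3CCN(C(=O)OC(C)(C)C)C3)n2)COc2ccccc21`, differs from compound 3 at the same place that all three measured steps touch, the group on the aromatic nitrogen: a group of 12 heavy atoms (9 carbon, 1 nitrogen, 2 oxygen; one five-membered non-aromatic ring with 1 hetero atom) in place of a group of 7 heavy atoms (6 carbon, 1 nitrogen; no ring), on an aromatic nitrogen

All three measured steps changed that group and stayed small, two of them within the scatter and one modest. For the measured compounds named here, none of them, however, brought in a ring, so no measured step shows what a five-membered non-aromatic ring with one hetero atom does here. On the evidence of compounds 1 to 3, a change at this position is expected to move the number little, and the direction is open. For compound 4 the step of a 1.3-fold lower number from compound 3 to compound 4 (0.11 log units; within the scatter) is therefore expected to be small, and the estimate for compound 4 in this assay is 3000 nM, with a range from 900 nM to 10000 nM.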

Compound 4, half-maximal effective concentration: > 10000 nM
Compound 4 ended at the assay's limit (the forecaster's own chance of this, stated with the estimate: 10%); at least 3.3-fold (0.52 log units) between middle value and limit.
By their numbers in this assay, from the lowest: compounds 1, 2 and 3 (each within the scatter of the next, the first and the last beyond it). At a limit, above all of these: compound 4.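

In this assay, compound 4 carries a limit of the assay and not a number: the limit of > 10000 nM in this assay, at which 1 of the 4 values shown sits.

The steps among compound 1, compound 2 and compound 3 only exchanged one open chain for another on the aromatic nitrogen, whereas this group brings in a five-membered non-aromatic ring with 1 hetero atom, and every comparison now lies beyond the scatter: an at least 2.6-fold higher number from compound 3 to compound 4 (0.41 log units; beyond the scatter), an at least 4.1-fold higher number from compound 2 to compound 4 (0.61 log units; beyond the scatter) and an at least 6.4-fold higher number from compound 1 to compound 4 (0.80 log units; beyond the scatter). Among the compounds shown here, the position is therefore less forgiving than the earlier compounds suggested, since a change here can raise the number clearly and not only slightly, and the true size of all three steps remains unknown.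

The ring, the larger size of the group and the carbonyl-bearing substituent on the nitrogen of that ring all enter together, so the compounds shown cannot separate their contributions. Also open, on these data alone, is whether the same ring with a free secondary amine, or an all-carbon five-membered ring, would read close to the open chains or would also end at the limit.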